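A few compounds are considered here, and "the series" means these few. Any claim that something is new, unique, unknown or untested is made for them only; others in the source may bear on it.

Compound 3 `CCCCCCCCc1ccc(OC(C)C(=O)Cn2nnc(-c3ccc(C(=O)O)cc3)n2)cc1` carries the lowest number of the three in an assay on microsomes from brain for inhibition of Fatty-acid amide hydrolase 1 (Rattus norvegicus), read by fluorescence and HPLC, with a stated time of 60 min (on this read-out higher numbers stand for weaker inhibition and lower numbers for stronger inhibition), at 50 nM, though its distance from both neighbours is within the scatter. Compound 1 `CC(Oc1ccc(Oc2ccc(Cl)cc2)cc1)C(=O)Cn1nnc(-c2ccccc2)n1` gives 51 nM in this assay, and compound 2 `CC(Oc1ccc(Oc2ccc(Cl)cc2)cc1)C(=O)Cn1nnc(-c2ccc(Cl)cc2)n1` gives 76 nM. Going by the values given here, the one measured step, a 1.5-fold higher number from compound 1 to compound 2 (0.17 log units; within the scatter), changes the aryl group on the tetrazole and leaves the aryloxy side of the core untouched. Compound 4 `CC(Oc1ccc(Oc2ccc(Cl)cc2)cc1)C(=O)Cn1nnc(-c2ccc(C(=O)O)cc2)n1` has not yet been measured; it differs from compound 3 by 4-chlorophenoxy in place of octyl on an aromatic carbon, the entering group being the same 4-chlorophenoxy that compounds 1 and 2 carry on their shared core, while the carboxylic acid of compound 3 is kept. Among the compounds with values here, no measured step covers this exchange directly. Compound 1 and compound 3 sit at the same level in this assay despite differing on both sides of the core, so the exchange is expected to move the number little, with the step of no change at the digits printed from compound 3 to compound 4 (within the scatter) estimated to stay within the scatter. Compound 4 is therefore estimated at 50 nM, with a range from 20 nM to 130 nM.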

Compound 4, half-maximal inhibitory concentration: 90 nM
Compound 4: the middle estimate sits 1.8-fold (0.26 log units) below what was measured, within the range that was stated.
By their numbers in this assay, from the lowest: compounds 3, 1, 2 and 4 (each within the scatter of the next).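

In this assay, 4-chlorophenoxy in place of octyl, with the carboxylic acid kept, gives a 1.8-fold higher number from compound 3 to compound 4 (0.26 log units; within the scatter), so the first exchange tested at this place, on an aromatic carbon para to a large group, stays within the scatter. With 4-chlorophenoxy held fixed, carboxy in place of hydrogen gives a 1.8-fold higher number from compound 1 to compound 4 (0.25 log units; within the scatter) and carboxy in place of chloro gives a 1.2-fold higher number from compound 2 to compound 4 (0.07 log units; within the scatter), so hydrogen, chloro and carboxy on that other aromatic carbon also cannot be told apart in this assay. No measurement offered here accounts for these small steps.

The compounds shown leave open whether an amine or a primary amide in place of the carboxylic acid would carry the number beyond the scatter. The same question stands for a shorter alkyl chain or a benzyloxy group in place of 4-chlorophenoxy.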